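A few compounds are considered here, and "the series" means these few. Any claim that something is new, unique, unknown or untested is made for them only; others in the source may bear on it.

Compound 2 `CC1=CC[C@H](C(C)C)c2cc(C)c(OC(=O)Nc3ccccc3)cc21` carries an anilino group on the carbonyl carbon of the ester-like linker attached to the shared core, and in a functional assay on PC-3 cells (Homo sapiens) for antiproliferative activity, read by sulforhodamine B assay, with a stated time of 48 h, tested at 50 uM (on this read-out lower numbers stand for less inhibition and higher numbers for more inhibition at the one concentration tested (going by the name of the read-out)), compound 2 gives 93.2%. That is the higher of the two numbers at hand: compound 1 `CC1=CC[C@H](C(C)C)c2cc(C)c(OC(=O)c3ccc(C)cc3)cc21`, with 4-methylphenyl in the same place, gives 49.6% in this assay, and the step of a number 43.6 percentage points higher from compound 1 to compound 2 (beyond the scatter) is large. Compound 3 `CC1=CC[C@H](C(C)C)c2cc(C)c(OC(=O)c3ccc([N+](=O)[O-])cc3)cc21` is not yet measured. The change 4-nitrophenyl in place of anilino on a carbonyl carbon undoes the anilino substitution and puts a 4-nitrophenyl group in its place, so compound 3 is again an aryl ester like compound 1, differing from compound 1 only in its 4-nitrophenyl rather than 4-methylphenyl group. Within the data shown here, the one step that bears on this is the large rise from compound 1 to compound 2, which compound 3 partly reverses. Compound 3 is therefore expected to fall, with a step of a number 38.2 percentage points lower from compound 2 to compound 3 (beyond the scatter) in this assay. The estimate for compound 3 is 55%, within a range from 30% to 85%.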

Compound 3, a percentage reported as inhibition, at one concentration (the size of the read-out at that concentration, not a potency): 36.7%
Compound 3: the middle estimate sits 18.3 percentage points above what was measured; measured number inside the range.
By their numbers in this assay, from the lowest: compound 3; then compound 1; then compound 2.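

In this assay, the change on the carbonyl carbon gives a number 56.5 percentage points lower from compound 2 to compound 3 (beyond the scatter), so a second aryl group in this place also stands far under the anilino compound, and the high number of compound 2 is not confined to a contrast with the 4-methylphenyl ester. The aryl esters themselves are not equal, though the difference is smaller: nitro in place of methyl on an aromatic carbon gives a number 12.9 percentage points lower from compound 1 to compound 3 (beyond the scatter), a modest step. Nothing available explains why the numbers move in these ways.

Going by these compounds, it remains open whether a 4-nitroanilino or 4-methylanilino group on the carbonyl carbon would keep the number of compound 2. On these data alone, whether a benzylamino or dimethylamino group would do the same is also open.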